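The compounds below may be only part of what the source reports. "The series", "measured", "known", "first", "only" and "open" are said of these compounds alone.

Notes on the series

The shared core is that of compound 1 `O=C(O)Cc1sc(C(c2ccccc2)c2ccccc2)nc1-c1ccccc1`, which in an in vitro assay on HEK385-7 cells for displacement of a labelled ligand from prostaglandin D2 receptor 2 (Homo sapiens) (on this read-out higher numbers stand for weaker inhibition and lower numbers for stronger inhibition), gives 570 nM. Compound 2 `O=C(O)Cc1sc(C(c2ccc(F)cc2)c2ccc(F)cc2)nc1-c1ccnc(F)c1` gives 0.48 nM in this assay and stands lowest of the two numbers shown; its nearest neighbour is compound 1, at a far higher number, a gap beyond the scatter. Compound 3 `COc1ccc(OC)c(-c2nc(C(c3ccccc3)c3ccccc3)sc2CC(=O)O)c1` carries 2,5-dimethoxyphenyl in place of phenyl on an aromatic carbon. For compound 3 the read-out in this assay is a limit, > 105 nM. The step that the limit leaves unreadable from compound 1 to compound 3 is therefore unreadable because of the limit of > 105 nM in this assay, at which 1 of the 3 values shown sits.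

Compound 4 `CN(C)c1cc(-c2nc(C(c3ccc(F)cc3)c3ccc(F)cc3)sc2CC(=O)O)ccn1` differs from compound 2 by dimethylamino in place of fluoro on an aromatic carbon. Within the data shown here, no measured step covers this change: the only step on record, from compound 1 to compound 3, concerns another ring and cannot be read, so the expectation rests on compound 2 alone, at 0.48 nM. The exchange enters a group of three heavy atoms where one stood, and some upward movement in this assay is expected rather than none. The expected step of an 8.3-fold higher number from compound 2 to compound 4 (0.92 log units; beyond the scatter) is taken as moderate and uncertain. Compound 4 is estimated at 4 nM in this assay, with a range from 0.5 nM to 40 nM.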

Compound 4, half-maximal inhibitory concentration: 380 nM
The estimate for compound 4 lay 95-fold (1.98 log units) below the measured number, and the stated range ends below it.
By their numbers in this assay, from the lowest: compound 2; then compounds 4 and 1 (each within the scatter of the next).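

In this assay, among these compounds, dimethylamino in place of fluoro next to the ring nitrogen gives a 790-fold higher number from compound 2 to compound 4 (2.90 log units; beyond the scatter), the only step that can be read, while the step to compound 3 cannot. With the rest of the molecule unchanged, this single exchange is enough to lose the low number of compound 2 at 0.48 nM, so that number depends on what this position carries and not only on the parts left in place. Nothing measured here accounts for the size of this step.

As far as these compounds go, what remains open is whether the step follows from losing fluoro or from the entry of dimethylamino, and a smaller group at this position, such as a primary amine, methoxy or plain hydrogen, would help separate the two. Compound 1 and compound 2 differ in more than one place, so the shares of the ring nitrogen and of the other fluoro groups in the low number of compound 2 also stay unresolved.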